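Moving a Chlorine Around the Fused Ring

The compounds below may be only part of what the source reports. "The series", "measured", "known", "first", "only" and "open" are said of these compounds alone.

Measured so far:
compound 1 `O=C(CCCc1ccccc1)Nc1nc2cc(Cl)ccc2c(=O)s1` — 76.4 nM
compound 2 `O=C(CCCc1ccccc1)Nc1nc2ccccc2c(=O)s1` — 34.9 nM

In an in vitro assay on cells for inhibition of Amine oxidase [flavin-containing] B (Homo sapiens), read by fluorescence and Amplex Red, with stated times of 30 min and 45 min (a higher number here means a weaker inhibitor, a lower number a stronger inhibitor), compound 2 gives the lower of the two numbers, and compound 1 the higher. Among the compounds with values here, the only measured step, a 2.2-fold lower number from compound 1 to compound 2 (0.34 log units; beyond the scatter), comes from hydrogen replacing chloro on an aromatic carbon. Compound 3 `O=C(CCCc1ccccc1)Nc1nc2ccc(Cl)cc2c(=O)s1` reverses that kind of change at a different carbon: chloro in place of hydrogen on an aromatic carbon. Because the related step was a 2.2-fold lower number from compound 1 to compound 2 (0.34 log units; beyond the scatter), a modest move toward a higher number is expected again. Compound 3 is therefore estimated at 60 nM, with a range of 25 nM to 150 nM. That estimate means an expected step of a 1.7-fold higher number from compound 2 to compound 3 (0.24 log units; within the scatter).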

Compound 3, half-maximal inhibitory concentration: > 10000 nM
Compound 3: a limit, no number (the forecaster's own chance of this, stated with the estimate: 2%); middle value at least 160-fold (2.22 log units) away from the limit.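

In this assay chloro on this carbon gives an at least 280-fold higher number from compound 2 to compound 3 (2.45 log units; beyond the scatter) while taking chloro off the carbon it occupies in compound 1 gave only a 2.2-fold lower number from compound 1 to compound 2 (0.34 log units; beyond the scatter) by comparison. Among these three compounds, then, where the chloro sits matters far more than its mere presence on the ring. Compound 3 stands at a limit, not at a number: the limit of > 10000 nM in this assay, at which 1 of the 3 values shown sits.

As far as these compounds go, how far past that limit compound 3 really lies stays unknown. From the compounds shown here alone, whether a smaller fluoro, a methyl or a methoxy on this same carbon would fall off as sharply also remains open.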